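The compounds below may be only part of what the source reports. "The series", "measured", "known", "first", "only" and "open" are said of these compounds alone.

Among the measured compounds shown here, in a functional assay (strain AB) with Danio rerio as the target, read by microscopy, with a stated time of 1 h (a higher number here means that more compound is needed for the effect, a lower number that less compound is needed), compound 1 `CC(C)(C)OC(=O)CCCN1CCc2c(sc(NC(=O)Nc3ccc(Cl)cc3)c2C(N)=O)C1` gives 560 nM, and compound 2 `NC(=O)c1c(NC(=O)Nc2ccc(Cl)cc2)sc2c1CCN(C1CCOCC1)C2` gives 2830 nM; the only measured step, a 5.1-fold higher number from compound 1 to compound 2 (0.70 log units; beyond the scatter), changes a substituent on the ring amine. Compound 3 `CCN1CCc2c(sc(NC(=O)[C@@H]3CCCN3)c2C(N)=O)C1` stands apart: in this assay compound 3 gives > 25000 nM, which is a limit of the assay rather than a number. It sits at the limit of > 25000 nM in this assay, at which 1 of the 3 values shown sits. Compound 4 `CCN1CCc2c(sc(N)c2C(N)=O)C1` differs from compound 3 by hydrogen in place of (pyrrolidin-2-yl)carbonyl on a nitrogen on an aromatic ring. For the measured compounds named here, no measured step touches this nitrogen on the aromatic ring, so the step from compound 1 to compound 2 gives no guide to its size or direction. Because compound 3 already rests at the limit of > 25000 nM in this assay, at which 1 of the 3 values shown sits, compound 4 is expected to give 30000 nM in this assay, within 12000 nM to 120000 nM, most likely again as a limit, so that the estimated step is a step that the limit leaves unreadable from compound 3 to compound 4.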

Compound 4, half-maximal effective concentration: > 25000 nM
Compound 4: only a limit was reported; the forecaster's own chance of this, stated with the estimate: 85%; the middle value does not contradict the limit.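

No step can be read from compound 3 to compound 4, since both rest at one limit, which is not a number: the limit of > 25000 nM in this assay, at which 2 of the 4 values shown sit.

The compounds shown leave open what hydrogen in place of (pyrrolidin-2-yl)carbonyl does in this assay.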